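The source may hold more compounds than are shown below. What is called first, only, known or untested is meant among the compounds shown, and "the series" means these compounds.

Compound 1 `CC(C)NC(=O)CC(c1ccc(-c2ccc3cccc(F)c3c2)[nH]c1=O)C(C)C` was tested in an assay on CHO cells for displacement of a labelled ligand from prostaglandin E2 receptor EP3 subtype (Homo sapiens), read by radioligand binding (a lower number here means a stronger inhibitor, a higher number a weaker inhibitor), where compound 1 gives 5.8 nM. Among the three measured compounds it holds the second highest number: compound 3 `CC(C)C(/C=C1/CCNC1=O)c1ccc(-c2ccc3cccc(F)c3c2)[nH]c1=O` lies nearest, with compound 3 giving 5.3 nM, while compound 2 `CC(C)C(Cc1nnn[nH]1)c1ccc(-c2ccc3cccc(F)c3c2)[nH]c1=O` lies furthest, with compound 2 giving 34 nM. The not yet measured compound 4 `CC(C)C(c1ccc(-c2ccc3cccc(F)c3c2)[nH]c1=O)N1CCCCS1(=O)=O` differs from compound 1 in one place: a group of 8 heavy atoms (4 carbon, 1 nitrogen, 2 oxygen, 1 sulfur; one six-membered non-aromatic ring with 2 hetero atoms) in place of a group of 7 heavy atoms (5 carbon, 1 nitrogen, 1 oxygen; no ring), on a saturated chain carbon bound to an aromatic carbon and a saturated chain carbon. Among the measured compounds shown here, two measured steps bear on this. The exchange of the chain for a five-membered ring gave a 1.1-fold lower number from compound 1 to compound 3 (0.04 log units; within the scatter), so a ring in this place can be carried without loss. The exchange for an aromatic ring with many hetero atoms gave a 5.9-fold higher number from compound 1 to compound 2 (0.77 log units; beyond the scatter), a modest weakening. The group entering in compound 4 carries no hydrogen-bond donor, unlike the groups of compound 1 and compound 3, so a modest weakening is expected, of about a 3.4-fold higher number from compound 1 to compound 4 (0.54 log units; beyond the scatter). For compound 4 in this assay the estimate is 20 nM, expected to fall between 6 nM and 70 nM.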

Compound 4, inhibition constant: 14 nM
Compound 4: the middle estimate sits 1.4-fold (0.15 log units) above what was measured, within the range that was stated.
By their numbers in this assay, from the lowest: compounds 3 and 1 (each within the scatter of the next); then compound 4; then compound 2.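

At this saturated chain carbon, a six-membered non-aromatic ring with 2 hetero atoms and 0 hydrogen-bond donors costs little in this assay (a 2.4-fold higher number from compound 1 to compound 4 (0.38 log units; beyond the scatter); a 2.6-fold higher number from compound 3 to compound 4 (0.42 log units; beyond the scatter)). The same group still gives a better result than the 1H-tetrazol-5-yl group (a 2.4-fold lower number from compound 2 to compound 4 (0.39 log units; beyond the scatter)), so the hydrogen-bond donor of the (isopropylcarbamoyl)methyl group is not required for a number in this range. No measurement is available that explains these differences.

The compounds shown do not separate the loss of the amide hydrogen from the change to the larger ring containing sulfur. From the compounds shown here alone, how a carboxylic acid, an amine or a longer chain would behave on this carbon remains open.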